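Pyridin-3-yl to aminomethyl on compound 2

The source may report more compounds than this note shows. Statements on the series, on what has been measured and on what is new or still open speak of the compounds shown alone.

In a functional assay on RAW264.7 cells (Mus musculus) for inhibition, read by Griess assay, with stated times of 3 h and 24 h (a lower number here means a stronger inhibitor, a higher number a weaker inhibitor), compound 1 (`C=C1CC[C@H]2[C@@](C)(CCC(=O)N[C@@]2(C)COC(=O)c2cccnc2)[C@@H]1/C=C/C1=CCOC1=O`) gives > 50000 nM, which is a limit of the assay and not a number. Compound 2 (`C=C1CC[C@H]2[C@@](C)(CC[C@@H](OC(=O)c3cccnc3)[C@@]2(C)NC=O)[C@@H]1/C=C/C1=CCOC1=O`) gives > 50000 nM, also only a limit, so its true position is not known. Among the measured compounds shown here, no step between measured compounds is available.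

Compound 3 (`C=C1CC[C@H]2[C@@](C)(CC[C@@H](OC(=O)CN)[C@@]2(C)NC=O)[C@@H]1/C=C/C1=CCOC1=O`) carries aminomethyl in place of pyridin-3-yl on a carbonyl carbon. In this assay no change beyond the scatter is expected, in either direction. This expectation rests only on compound 2 with its limit of > 50000 nM, and a further limit is the likeliest report. The estimated change is a number no higher from compound 2 to compound 3 (the limit leaves the size open). For compound 3 the expected value is 50000 nM, with an estimated range of 20000 nM to 100000 nM.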

Compound 3, half-maximal inhibitory concentration: > 50000 nM
Compound 3: no number, only a limit; the forecaster's own chance of this, stated with the estimate: 70%; the middle value sits exactly at the limit.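

In this assay compound 3 gives > 50000 nM, which is a limit and not a number. Among the compounds shown here, compound 2 also stands only at a limit, so no step from compound 2 to compound 3 can be read. The compounds shown leave open what true potency any of them has, and whether aminomethyl in place of pyridin-3-yl changes it.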